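Ester and methylsulfonyl variants in a liver-cell toxicity test

The compounds below may be only part of what the source reports. "The series", "measured", "known", "first", "only" and "open" are said of these compounds alone.

Compound 1 `CC(C)N(Cc1cccc(OCCCCCC(=O)O)c1)C(=O)c1ccc(-c2cccc(Cl)c2)cc1`: in an ADME assay on HepG2 cells (Homo sapiens) for cytotoxicity, read by CellTiter-Glo and resazurin assay, with a stated time of 72 h (on this read-out higher numbers stand for an effect only at larger amounts of compound and lower numbers for an effect already at smaller amounts), compound 1 gives > 21900 nM, which is a limit of the test rather than a number.
Compound 2 `CC(C)N(Cc1cccc(OCCCCCC(=O)O)c1)C(=O)c1ccc(-c2cccc(S(C)(=O)=O)c2)cc1`: in this assay compound 2 gives > 26000 nM, also a limit.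
Compound 3 `CCOC(=O)CCCCCOc1cccc(CN(C(=O)c2ccc(-c3cccc(Cl)c3)cc2)C(C)C)c1`: in this assay compound 3 gives > 18400 nM, again a limit.

Compound 4 `CCOC(=O)CCCCCOc1cccc(CN(C(=O)c2ccc(-c3cccc(S(C)(=O)=O)c3)cc2)C(C)C)c1` has not yet been measured. It differs from compound 3 by one change, (methylsulfonyl in place of chloro on an aromatic carbon). The same change has already been made once, from compound 1 to compound 2, (methylsulfonyl in place of chloro on an aromatic carbon), where the outcome was a step that the two limits leave unreadable from compound 1 to compound 2. The two cores on which this change sits differ by ethyl in place of hydrogen on an oxygen next to a carbonyl group; the place of the change reads the same in both cases, so it is the same change on two different cores. For the measured compounds named here, because every value so far sits at a limit, (the limit of > 18400 nM in this assay, at which 1 of the 3 values shown sits), (the limit of > 21900 nM in this assay, at which 1 of the 3 values shown sits), (the limit of > 26000 nM in this assay, at which 1 of the 3 values shown sits), no readable step is available to lean on. What the values do show is that none of the three compounds reached a measurable effect within the tested range. The expected step is estimated as a step that the limit leaves unreadable from compound 3 to compound 4. Compound 4 is therefore expected to come out near 30000 nM in this assay, most likely once more as a limit.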

Compound 4, half-maximal effective concentration: > 26000 nM
Compound 4 was reported as a limit; the forecaster's own chance of this, stated with the estimate: 85%; the middle value lies beyond the limit too.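

In this assay compound 4 gives > 26000 nM, which is a limit of the test, so neither its step from compound 3 nor its step from compound 2 can be read. The compounds shown leave open at what concentration, if any, compounds 1 to 4 would affect these cells, and whether either change would then matter.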